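The source may report more compounds than this note shows. Statements on the series, on what has been measured and on what is new or still open speak of the compounds shown alone.

Compound 1 `CS(=O)(=O)c1ccc(C(=O)NCCC(=O)N2CCCCC2)cc1[N+](=O)[O-]` was run in an ADME assay on HepG2 cells (Homo sapiens) for cytotoxicity, read by CellTiter-Glo and ATP content, with a stated time of 72 h (a lower number here means that less compound is needed, a higher number that more compound is needed for the effect), and returned only the assay limit, > 27000 nM. Compound 2 `CN(Cc1ccccc1)C(=O)CNC(=O)c1ccc(S(C)(=O)=O)c([N+](=O)[O-])c1` likewise reached only a limit in this assay, > 27000 nM. Compound 3 `CS(=O)(=O)c1ccc(C(=O)NCCC(=O)N2CCc3ccccc3C2)cc1[N+](=O)[O-]` also stands at a limit in this assay, > 27000 nM. Among the compounds with values here, the single one-point change among the measured compounds, a step that the two limits leave unreadable from compound 1 to compound 3, cannot be sized because both ends are limits, and all that this assay has established so far is the limit of > 27000 nM in this assay, at which 3 of the 3 values shown sit. Compound 4 `CS(=O)(=O)c1ccc(C(=O)NCCCC(=O)N2CCCCC2)cc1[N+](=O)[O-]` differs from compound 1 by ((piperidin-1-yl)carbonyl)methyl in place of (piperidin-1-yl)carbonyl on a saturated chain carbon, two bonds along the chain from an amide-type nitrogen, a lengthening of the chain carrying the piperidinyl carbonyl. Within the data shown here, no measured step bears readably on this change, and nothing suggests a step beyond the scatter in this assay; the expectation is that compound 4 again sits at the limit rather than giving a number. Compound 4 is therefore estimated at 30000 nM in this assay, with a range of 15000 nM to 70000 nM. The expected step from compound 1 to compound 4 in this assay is a step that the limit leaves unreadable from compound 1 to compound 4, with the measurement to follow.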

Compound 4, half-maximal effective concentration: > 27000 nM
Compound 4: no number, only a limit; the forecaster's own chance of this, stated with the estimate: 85%; the middle value is on the limit's open side.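

Compound 1 and compound 4 both stand only at a limit in this assay, so the step between them cannot be read: the limit of > 27000 nM in this assay, at which 4 of the 4 values shown sit. The compounds shown leave open whether any structure in this series gives a number in this assay rather than a limit.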